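Swapping the heteroaryl on the sulfonamide of compound 1

This account rests on a few compounds, and the source may have more. Where it says the series, first, only, none or still open, it means among the compounds named here.

Among the compounds with values here, compound 1, `C=C1CC[C@@H]2[C@](C)(COC(C)=O)[C@H](OC(C)=O)CC[C@@]2(C)[C@H]1CC(Nc1ccc(S(=O)(=O)Nc2cc(C)on2)cc1)C1=CCOC1=O`, is one of two compounds measured in a functional assay on SK-MEL-2 cells (Homo sapiens) for inhibition, read by sulforhodamine B assay, with a stated time of 48 h (a lower number here means a stronger inhibitor of growth, a higher number a weaker inhibitor of growth), where compound 1 gives 4400 nM. Its companion, compound 2, `C=C1CC[C@@H]2[C@](C)(COC(C)=O)[C@H](OC(C)=O)CC[C@@]2(C)[C@H]1CC(Nc1ccc(S(=O)(=O)Nc2ncccn2)cc1)C1=CCOC1=O`, shares the same core and differs only at the sulfonamide nitrogen; in this assay compound 2 gives 7200 nM. The only step recorded between them is a 1.6-fold higher number from compound 1 to compound 2 (0.21 log units; within the scatter), so on the numbers shown compound 1 has the lowest value, and compound 2 stands within the scatter of it.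

Compound 3, `C=C1CC[C@@H]2[C@](C)(COC(C)=O)[C@H](OC(C)=O)CC[C@@]2(C)[C@H]1CC(Nc1ccc(S(=O)(=O)Nc2nccs2)cc1)C1=CCOC1=O`, is not yet measured. Its difference from compound 1 is 1,3-thiazol-2-yl in place of 5-methyl-1,2-oxazol-3-yl on a sulfonamide nitrogen. Within the data shown here, the one step that bears on this change is the exchange of the same heteroaryl for pyrimidin-2-yl, which gave a 1.6-fold higher number from compound 1 to compound 2 (0.21 log units; within the scatter), a shift that stayed inside the scatter. Because that step, a 1.6-fold higher number from compound 1 to compound 2 (0.21 log units; within the scatter), was small, the replacement by another small five-membered heteroaryl in compound 3 is expected to give at most a modest shift, with no direction beyond the scatter established. Compound 3 is therefore estimated at 5500 nM in this assay, with a range from 2500 nM to 12000 nM, which corresponds to an expected step of a 1.3-fold higher number from compound 1 to compound 3 (0.10 log units; within the scatter).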

Compound 3, concentration for total growth inhibition: 24300 nM
Compound 3: the middle estimate sits 4.4-fold (0.65 log units) below what was measured; measured number outside the range, above it.
By their numbers in this assay, from the lowest: compounds 1 and 2 (each within the scatter of the next); then compound 3.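

The sulfonamide nitrogen turns out not to be indifferent to the heteroaryl it carries. In this assay, 1,3-thiazol-2-yl in place of 5-methyl-1,2-oxazol-3-yl gave a 5.5-fold higher number from compound 1 to compound 3 (0.74 log units; beyond the scatter), and the same group in place of pyrimidin-2-yl gave a 3.4-fold higher number from compound 2 to compound 3 (0.53 log units; beyond the scatter), which makes compound 3 the weakest inhibitor of growth of the three. The earlier exchange had stayed inside the scatter, whereas this one shows that two groups, each one five-membered aromatic ring with 2 hetero atoms, can differ beyond it, although no measurement shown here accounts for that difference.

The change from compound 1 to compound 3 alters the ring hetero atoms and removes the methyl in a single step, so the compounds shown cannot assign the loss to either alteration. On these data alone, a 5-methyl-1,3-thiazol-2-yl or an unsubstituted 1,2-oxazol-3-yl on the sulfonamide nitrogen would separate the two, and how a six-membered ring other than pyrimidin-2-yl, such as pyridin-2-yl, would behave at this position remains open.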